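Solubility notes on a urea pair and a proposed analogue

The source may hold more compounds than are shown below. What is called first, only, known or untested is meant among the compounds shown, and "the series" means these compounds.

Among the compounds with values here, the series so far covers two ureas sharing one core. Compound 1 `COc1ccc(NC(=O)Nc2cc(C)nc3ccccc23)cc1` in a physicochemical assay for solubility, at pH 7.4 (on this read-out higher numbers stand for higher solubility and lower numbers for lower solubility), gives 19800 nM. Compound 2 `Cc1cc(NC(=O)Nc2ncccc2C)c2ccccc2n1` in this assay gives 1300 nM, the lowest of the two numbers; the nearest value, that of compound 1, stands well above it, and the gap between the two lies beyond the usual scatter. Within the data shown here, no step between measured compounds differing in a single place is available, so the series offers no direct precedent for any one change.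

The next compound, compound 3 `Cc1cc(NC(=O)Nc2ccc(N)cc2)c2ccccc2n1`, has not yet been measured. It differs from compound 2 as follows: 4-aminophenyl in place of 3-methylpyridin-2-yl on an amide-type nitrogen. Because compound 1 gives 19800 nM with a ring of carbon only on the corresponding nitrogen, the value of compound 3 is expected to move upward from that of compound 2 by a step larger than the scatter, namely a 12-fold higher number from compound 2 to compound 3 (1.06 log units; beyond the scatter). For compound 3 the solubility is estimated at 15000 nM, within a range from 4000 nM to 60000 nM.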

Compound 3, solubility: 18500 nM
Compound 3: the middle estimate sits 1.2-fold (0.09 log units) below what was measured, and the stated range covers the measured number.
By their numbers in this assay, from the lowest: compound 2; then compounds 3 and 1 (each within the scatter of the next).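

In this assay, within the data shown here, the exchange of 3-methylpyridin-2-yl for 4-aminophenyl on an amide-type nitrogen gives a 14-fold higher number from compound 2 to compound 3 (1.15 log units; beyond the scatter) and so supplies a direct single-place reading at this nitrogen, which the earlier compounds lacked; the step is large and beyond the scatter. The second step, amino in place of methoxy on an aromatic carbon, gives a 1.1-fold lower number from compound 1 to compound 3 (0.03 log units; within the scatter) and lies within the scatter, which means that the two groups cannot be told apart on this read-out when they sit on the ring of carbon only. Nothing measured in the series speaks to the origin of either step.

The step from compound 2 changes the ring and its substituent together, and the compounds shown do not separate the contributions of the ring nitrogen, the methyl group and the amino group. Also open, from the compounds shown here alone, is whether a plain unsubstituted phenyl, a pyridinyl ring carrying no methyl, or a carboxylic acid or dimethylamino group in place of the amino group would stay level with compound 1 and compound 3 or fall toward compound 2.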